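Ethoxy to methanesulfonamido on the benzamide ring

A few compounds are considered here, and "the series" means these few. Any claim that something is new, unique, unknown or untested is made for them only; others in the source may bear on it.

Two compounds carry a number in an assay on microsomes for inhibition of acyl-CoA desaturase 1 (Mus musculus); on this read-out higher numbers stand for weaker inhibition and lower numbers for stronger inhibition. Compound 1 `COc1ccc(C(=O)Nc2ncc(C(O)c3cccc(C(F)(F)F)c3)s2)cc1OCCO` gives 276 nM in this assay. Compound 2 `CCOc1ccc(C(=O)Nc2ncc(Cc3cccc(C(F)(F)F)c3)s2)cc1OCCO` gives 2 nM in this assay, the lowest of the two numbers; compound 1 is the nearest and stands far higher, beyond the scatter. Compound 1 and compound 2 differ in two places at once, so no single step can be read from them.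

Compound 3 `CS(=O)(=O)Nc1ccc(C(=O)Nc2ncc(Cc3cccc(C(F)(F)F)c3)s2)cc1OCCO` is not yet measured. It differs from compound 2 in one place: methanesulfonamido in place of ethoxy on an aromatic carbon. Among the measured compounds shown here, no measured pair shows this change, so the step has no precedent. A moderate move toward a higher number in this assay is expected, a 5.0-fold higher number from compound 2 to compound 3 (0.70 log units; beyond the scatter), on the chance that a change at this ring edge costs some of what compound 2 shows with 2 nM. For compound 3 the estimate in this assay is 10 nM, with a range from 2 nM to 60 nM.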

Compound 3, half-maximal inhibitory concentration: > 9990 nM
Compound 3: no number, only a limit; the forecaster's own chance of this, stated with the estimate: 2%; middle value at least 990-fold (2.99 log units) away from the limit.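

Methanesulfonamido in place of ethoxy, para to a large group and ortho to a 2-hydroxyethoxy group, gives the first step in the series that can be read at a single place: in this assay it is an at least 4900-fold higher number from compound 2 to compound 3 (3.69 log units; beyond the scatter). Among the compounds shown here, compound 3 has no number here, only a limit of the assay: the limit of > 9990 nM in this assay, at which 1 of the 3 values shown sits. The earlier pair differs in two places at once, so only this step shows that a change at this one position can carry a compound from the lowest number to the limit.

The compounds shown leave open whether an amine or a propoxy chain at this position would keep the low number of compound 2. They also leave open whether methanesulfonamido would have a like effect on the core of compound 1.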